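This account rests on a few compounds, and the source may have more. Where it says the series, first, only, none or still open, it means among the compounds named here.

Of the compounds shown here, two of the shared core carry the measured values so far. Compound 1 `COc1cc2ncnc(Nc3ccc(F)c(Cl)c3)c2cc1OCCCSc1nc2ccccc2s1` gives 5370 nM in a functional assay on MCF7 cells (Homo sapiens) for cytotoxicity, read by MTT assay, with a stated time of 24 h; on this read-out higher numbers stand for weaker inhibition and lower numbers for stronger inhibition. Compound 2 `COc1cc2ncnc(Nc3ccc(OC(F)(F)F)cc3)c2cc1OCCCSc1nc2ccccc2o1` gives 9080 nM in this assay, a value that sits within the scatter of compound 1, so the two are not distinguished. Compound 3 `COc1cc2ncnc(Nc3ccc(C)cc3)c2cc1OCCCSc1nc2ccccc2o1` differs from compound 2 by methyl in place of trifluoromethoxy on an aromatic carbon. Going by the values given here, no measured pair with a change of this kind is available, so the step is expected to be small, not beyond the scatter in either direction, as a 1.1-fold lower number from compound 2 to compound 3 (0.05 log units; within the scatter). On that basis compound 3 is estimated at 8000 nM, with a range from 3000 nM to 25000 nM.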

Compound 3, half-maximal inhibitory concentration: 12100 nM
Beside the measured number, compound 3's estimate is 1.5-fold (0.18 log units) below it; measured number inside the range.
By their numbers in this assay, from the lowest: compounds 1, 2 and 3 (each within the scatter of the next, the first and the last beyond it).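

In this assay methyl in place of trifluoromethoxy gives a 1.3-fold higher number from compound 2 to compound 3 (0.12 log units; within the scatter) at this aromatic carbon, para to a large group. This first step that changes one place only does not separate the two groups, so this position accepts either one without a difference that can be read on this assay. No measured evidence bears on this result.

As far as these compounds go, whether an amine, a carboxylic acid or a longer alkyl chain on this carbon would move the number beyond the scatter remains open. Also open, from the compounds shown here alone, is whether the same change reads alike with the end group of compound 1.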